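Replacing chloro with ethoxy on compound 2

The source may hold more compounds than are shown below. What is called first, only, known or untested is meant among the compounds shown, and "the series" means these compounds.

In a functional assay on LoVo cells (Homo sapiens) for inhibition, read by MTT assay, with a stated time of 72 h (a lower number here means a stronger inhibitor, a higher number a weaker inhibitor), compound 1 `C=C(Br)C(=O)Nc1cccc(/C=C/C(=O)Nc2cccc(F)c2)c1` gives 1000 nM, compound 3 `C=C(Br)C(=O)Nc1cccc(/C=C/C(=O)NCc2ccc(C)cc2)c1` gives 1900 nM, and compound 2 `C=C(Br)C(=O)Nc1cccc(/C=C/C(=O)Nc2ccc(Cl)cc2)c1` gives 5900 nM, the highest number and so the weakest inhibitor of the three. Compound 4 `C=C(Br)C(=O)Nc1cccc(/C=C/C(=O)Nc2ccc(OCC)cc2)c1` has ethoxy in place of chloro on an aromatic carbon, para to a large group: ethoxy in place of chloro on an aromatic carbon. Going by the values given here, no measured step makes this exact change. The closest evidence comes from changing the group on the amide-type nitrogen, with a 5.9-fold higher number from compound 1 to compound 2 (0.77 log units; beyond the scatter) and a 3.1-fold lower number from compound 2 to compound 3 (0.49 log units; beyond the scatter). Both neighbours of compound 2 sit lower, so a small move towards a lower number is expected. The expected step is a 2.1-fold lower number from compound 2 to compound 4 (0.32 log units; beyond the scatter). For compound 4 the estimated value is 2800 nM, with an expected range of 900 nM to 8000 nM.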

Compound 4, half-maximal inhibitory concentration: 850 nM
Compound 4: the middle estimate sits 3.3-fold (0.52 log units) above what was measured; the whole stated range lies above it.
By their numbers in this assay, from the lowest: compounds 4, 1 and 3 (each within the scatter of the next, the first and the last beyond it); then compound 2.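

Exchanging chloro for ethoxy on an aromatic carbon, para to a large group, gives a 6.9-fold lower number from compound 2 to compound 4 (0.84 log units; beyond the scatter) in this assay. The earlier compounds shown here changed the whole group on the amide-type nitrogen, whereas this step shows that a single substituent on that ring can itself shift the number beyond the scatter. No measurement shown here explains why this exchange has that effect.

The compounds shown cannot separate the role of the oxygen from that of the two-carbon chain. From the compounds shown here alone, it also remains open how methoxy, butoxy or an amine would behave at this place.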